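An ester in place of the thiazolyl amide

A few compounds are considered here, and "the series" means these few. Any claim that something is new, unique, unknown or untested is made for them only; others in the source may bear on it.

Compound 1 `O=C(N[C@@H](CCCCCCSSc1ccccn1)C(=O)Nc1nc(-c2ccccc2)cs1)OCc1ccccc1` gives 3200 nM in a functional assay on MCF7 cells (Homo sapiens) for antiproliferative activity, read by MTT assay, with a stated time of 48 h (a lower number here means a stronger inhibitor, a higher number a weaker inhibitor), the lowest of the two numbers recorded so far. Compound 2 `O=C(N[C@@H](CCCCCCSSc1ccccn1)C(=O)Nc1ccccc1-c1ccccc1)OCc1ccccc1` gives 20800 nM in this assay, and the step of a 6.5-fold higher number from compound 1 to compound 2 (0.81 log units; beyond the scatter) shows that exchanging the group on the amide-type nitrogen weakens inhibition. Compound 3 `O=C(N[C@@H](CCCCCCSSc1ccccn1)C(=O)OCc1ccc2ccccc2c1)OCc1ccccc1` is not yet measured; it differs from compound 1 by (naphthalen-2-yl)methoxy in place of (4-phenyl-1,3-thiazol-2-yl)amino on a carbonyl carbon. Going by the values given here, only that single step bears on this change, and it was modest and beyond the scatter, so a weakening of similar size is expected here. Compound 3 is therefore estimated at 12000 nM, within 4000 nM to 40000 nM, an expected step of a 3.8-fold higher number from compound 1 to compound 3 (0.57 log units; beyond the scatter).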

Compound 3, half-maximal inhibitory concentration: 14800 nM
Beside the measured number, compound 3's estimate is 1.2-fold (0.09 log units) below it; the measured number falls inside the stated range.
By their numbers in this assay, from the lowest: compound 1; then compounds 3 and 2 (each within the scatter of the next).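

In this assay, (naphthalen-2-yl)methoxy in place of (4-phenyl-1,3-thiazol-2-yl)amino on the carbonyl carbon gives a 4.6-fold higher number from compound 1 to compound 3 (0.67 log units; beyond the scatter), so a second, different replacement at this position also fails to match compound 1. This change swaps the linking atom and the ring system together, and the group that enters has no hydrogen-bond donor. No evidence is available that explains the loss. The compounds shown leave the two parts of this change unseparated. A (naphthalen-2-yl)methylamino group would show what the linking oxygen contributes apart from the naphthalene.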